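Series notes: the step from compound 3 to compound 4

The source may hold more compounds than are shown below. What is called first, only, known or untested is meant among the compounds shown, and "the series" means these compounds.

compound 1 `Cc1nccnc1C1CN2CCC1CC2`: 4%
compound 2 `Clc1cncc(C2CN3CCC2CC3)n1`: 8%
compound 3 `CCCCCCOc1nccnc1[C@@H]1CN2CCCC1C2`: 4%

All three numbers come from a functional assay on A9L-m1 cells with A9 (Mus musculus) as the target; a higher number here means a larger maximal response, a lower number a smaller maximal response. Compound 3 stands level with compound 1 at the digits shown and, together with it, forms the lowest pair of the three. Its nearest neighbour is compound 1, with no change at the digits shown, inside the scatter. Its furthest neighbour is compound 2, which sits slightly higher, yet that gap also lies inside the scatter. Taken together, the three measured compounds all sit close to the bottom of the scale, with no separation among them that counts as real.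

Compound 4 `CCCCCCOc1nccnc1[C@H]1CN2CCCC1C2` has not been measured. Its difference from compound 3 is the two compounds have the same atoms and bonds; at least one stereo element is drawn with a configuration in one of them and without one in the other: 1 of 3 stereo elements differ; a stereocentre at a saturated ring carbon is drawn S in compound 3 and R in compound 4. Nothing leaves and nothing enters.

Within the data shown here, no step between two measured compounds is available here, so there is no measured reference for what this kind of change does in this assay. With compound 3 giving 4% and the whole measured set sitting low, the step of a number 1 percentage points higher from compound 3 to compound 4 (within the scatter) is expected to stay within the scatter, in no particular direction. Compound 4 is estimated at 5%, with a range from 0% to 15%.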

Compound 4, largest response reached (reported as maximum), in percent of the reference or control that the assay uses: 12%
The estimate for compound 4 lay 7 percentage points below the measured number; low and high end bracket the measured number.
By their numbers in this assay, from the lowest: compounds 1, 3, 2 and 4 (each within the scatter of the next).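

In this assay, among these compounds, the stereocentre at a saturated ring carbon, drawn S in compound 3 and R in compound 4, provides the first measured pair that differs in one place, with a step of a number 8 percentage points higher from compound 3 to compound 4 (within the scatter). This change of configuration therefore produces no separation that counts as real, and neither drawing lifts the maximal response clear of the other measured compounds. The pair also needs one qualification in its reading, as the two stereo drawings are not fully matched: the fact that one of compounds 3 and 4 is drawn with a defined configuration and the other without, at the place where they differ.

The compounds shown leave open whether this stereocentre would matter on a background that gives a clearly larger maximal response, since this single pair stays within the scatter. They also leave open how the two configurations compare when the ether chain of compounds 3 and 4 is replaced by a longer chain or an amine, and whether the other stereo elements of the shared core influence the response.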